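The compounds below may be only part of what the source reports. "The series", "measured", "known", "first", "only" and "open" are said of these compounds alone.

Two compounds measured in an assay on cells for antagonist activity at Toll-like receptor 4 (Homo sapiens), with a stated time of 24 h (on this read-out higher numbers stand for weaker inhibition and lower numbers for stronger inhibition), share the same core and differ only in the group on the outer aromatic ring. Compound 1 `Cc1nn(Cc2ccccc2Cl)c(C)c1CN(C)CC(O)CCOc1ccc(F)cc1` carries a fluoro on that ring, and in this assay compound 1 gives 55400 nM. Compound 2 `CCc1ccc(OCCC(O)CN(C)Cc2c(C)nn(Cc3ccccc3Cl)c2C)cc1` carries an ethyl in place of the fluoro, and in this assay compound 2 gives 26000 nM. Among the measured compounds shown here, the single step between them reads a 2.1-fold lower number from compound 1 to compound 2 (0.33 log units; beyond the scatter), a modest change in the direction of stronger inhibition. For the measured compounds named here, compound 2 therefore stands at the lowest of the two numbers known so far.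

Compound 3 `CCCc1ccc(OCCC(O)CN(C)Cc2c(C)nn(Cc3ccccc3Cl)c2C)cc1` grows the same substituent by one step: methyl in place of hydrogen on a saturated chain carbon, two bonds along the chain from an aromatic carbon. Going by the values given here, the only comparison available is the step from compound 1 to compound 2, and it concerns a different exchange, fluoro for ethyl, rather than ethyl for propyl. Because that step of a 2.1-fold lower number from compound 1 to compound 2 (0.33 log units; beyond the scatter) went toward lower numbers as the group lengthened, a small further step in the same direction is expected, though it may not exceed the scatter. Compound 3 is estimated at 18000 nM, with a range from 7000 nM to 45000 nM, which means an expected step of a 1.4-fold lower number from compound 2 to compound 3 (0.16 log units; within the scatter).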

Compound 3, half-maximal inhibitory concentration: 24700 nM
Estimate against measurement, compound 3: 1.4-fold (0.14 log units) below; the measured number falls inside the stated range.
By their numbers in this assay, from the lowest: compounds 3 and 2 (each within the scatter of the next); then compound 1.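

In this assay, turning the ethyl of compound 2 into the propyl of compound 3, with methyl in place of hydrogen on a saturated chain carbon, two bonds along the chain from an aromatic carbon, gives a 1.1-fold lower number from compound 2 to compound 3 (0.02 log units; within the scatter), so this added methyl brings no change that can be read. Set against the fluoro group, the propyl gives a 2.2-fold lower number from compound 1 to compound 3 (0.35 log units; beyond the scatter), close in size to a 2.1-fold lower number from compound 1 to compound 2 (0.33 log units; beyond the scatter), which means that both chains stand apart from fluoro while the two chains cannot be told apart from each other; the trend from the first step therefore does not continue with further lengthening, and compound 3 goes against any claim of a steady fall with chain length. No measurement at hand explains why this extension changes so little.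

From the compounds shown here alone, whether a longer chain such as butyl, or a branched group such as isopropyl, would read differently from ethyl and propyl remains open. Also open is how the number would respond to an amine or a carboxylic acid on the same aromatic carbon, as the groups shown there are only fluoro, ethyl and propyl.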